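Swapping the pyridine substituent on a thiosemicarbazide series

The source may hold more compounds than are shown below. What is called first, only, known or untested is meant among the compounds shown, and "the series" means these compounds.

Measured compounds:
compound 1, `Cc1cccc(/C(N)=N/NC(=S)N2CCCCC2)n1`, 85.7%
compound 2, `N/C(=N\NC(=S)N1CCOCC1)c1ccc(F)cn1`, 86.2%
compound 3, `N/C(=N\NC(=S)N1CCN(c2ccccn2)CC1)c1ccc(F)cn1`, 76.2%

All three compounds share a thiosemicarbazide core and were tested in a functional assay on A-375 cells (Homo sapiens) for cytotoxicity, read by MTT assay, with a stated time of 72 h, tested at 100 uM; a lower number here means less inhibition of growth, a higher number more inhibition of growth at the concentration tested. Compound 3 gives the lowest of the three numbers, yet its gap to compound 1 and its gap to compound 2 both lie within the usual scatter of this kind of measurement, so the three values cannot be told apart with confidence.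

Compound 4, `Cc1ccnc(/C(N)=N/NC(=S)N2CCN(c3ccccn3)CC2)c1`, has not yet been measured in this assay. It differs from compound 3 in one place only: 4-methylpyridin-2-yl in place of 5-fluoropyridin-2-yl on a carbon with a double bond to nitrogen. Among the measured compounds shown here, no pair among the measured compounds differs in a single place, so there is no measured step to lean on; the only hint is that compound 1, which also carries a methyl-bearing pyridine, sits within the scatter of compound 2 and compound 3.

On that basis no step beyond the scatter is expected in this assay for the change from compound 3 to compound 4, which is estimated as a number 2.8 percentage points higher from compound 3 to compound 4 (within the scatter). Compound 4 is therefore expected to give about 79%, most likely between 63% and 91%.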

Compound 4, percent growth inhibition at one concentration: 81%
The estimate for compound 4 lay 2 percentage points below the measured number, within the range that was stated.
By their numbers in this assay, from the lowest: compounds 3, 4, 1 and 2 (each within the scatter of the next).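

Among the compounds shown here, this is the first pair that differs in one place only, so the pyridine group on the carbon with a double bond to nitrogen can now be judged on its own. In this assay, putting 4-methylpyridin-2-yl in place of 5-fluoropyridin-2-yl gives a number 4.8 percentage points higher from compound 3 to compound 4 (within the scatter), so this exchange produces no change that can be told from the scatter at the one concentration tested. Nothing measured here offers an explanation for this result.

Still open, from the compounds shown here alone, is whether a different group in this place, such as a phenyl ring, a carboxylic acid or a longer alkyl chain, would shift the number beyond the scatter. Also open, going by these compounds, is whether compound 3 and compound 4 would remain alike at lower concentrations.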